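Adding a second methoxy to compound 2

This account rests on a few compounds, and the source may have more. Where it says the series, first, only, none or still open, it means among the compounds named here.

compound 1 `C=C(Br)C(=O)Nc1cccc(/C=C/C(=O)NCc2ccc(C)cc2)c1` 550 nM
compound 2 `C=C(Br)C(=O)Nc1cccc(/C=C/C(=O)Nc2ccc(OC)cc2)c1` 26 nM

In a functional assay on CCRF-CEM cells (Homo sapiens) for inhibition, read by MTT assay, with a stated time of 72 h (a lower number here means a stronger inhibitor, a higher number a weaker inhibitor), compound 2 holds the lower of the two numbers. Within the data shown here, the only measured step is a 21-fold lower number from compound 1 to compound 2 (1.33 log units; beyond the scatter) on placing 4-methoxyphenyl where 4-methylbenzyl stood on an amide-type nitrogen. Compound 3 `C=C(Br)C(=O)Nc1cccc(/C=C/C(=O)Nc2ccc(OC)c(OC)c2)c1` keeps that group and adds methoxy in place of hydrogen on an aromatic carbon as methoxy in place of hydrogen on an aromatic carbon, ortho to a methoxy group. That large step tested a different change, so it sets no size here. A slightly higher number, possibly within the scatter, is expected. The estimated move is a 1.5-fold higher number from compound 2 to compound 3 (0.19 log units; within the scatter) in this assay terms. Compound 3 is estimated at 40 nM with 12 nM to 130 nM as its expected range.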

Compound 3, half-maximal inhibitory concentration: 21 nM
Estimate against measurement, compound 3: 1.9-fold (0.28 log units) above; measured number inside the range.
By their numbers in this assay, from the lowest: compounds 3 and 2 (each within the scatter of the next); then compound 1.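

In this assay, methoxy in place of hydrogen on an aromatic carbon, ortho to a methoxy group, gives a 1.2-fold lower number from compound 2 to compound 3 (0.09 log units; within the scatter). Among these compounds, this is the first view of a change on the aromatic ring itself, and it shows that this position takes a methoxy with no change that can be told from the scatter. Nothing measured here gives a reason for this result.

As far as these compounds go, whether this position accepts other groups stays open, such as an amine, a carboxylic acid or a longer chain like ethoxy. Methoxy alone cannot show how far that tolerance extends.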